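Changing One Ring on a Weakly Active Series

The compounds below may be only part of what the source reports. "The series", "measured", "known", "first", "only" and "open" are said of these compounds alone.

In a functional assay on GBM3 cells (Homo sapiens) for antiproliferative activity, read by WST assay, with a stated time of 72 h (a higher number here means a weaker inhibitor, a lower number a stronger inhibitor), compound 1 (`O=C(Nc1cc2ncncc2cc1OCc1ccc(Cl)cc1)Nc1cccc2ccccc12`) gives 7700 nM as the highest of three numbers, clearly above compound 2 (`O=C(Nc1cccc(Cl)c1)Nc1cc2ncncc2cc1OCc1cccc(Cl)c1`) at 3500 nM and compound 3 (`O=C(Nc1ccccc1F)Nc1cc2ncncc2cc1OCc1ccccc1F`) at 3800 nM in the same test. Compound 4 (`O=C(Nc1cc2ncncc2cc1OCc1cccc(F)c1)Nc1cccc2ccccc12`) has 3-fluorophenyl in place of 4-chlorophenyl on a saturated chain carbon bound to an oxygen on an aromatic ring. For the measured compounds named here, no two measured compounds differ in one place only, so this change has no direct precedent. Compound 3 also carries fluorine in that part and stands at 3800 nM as a loose guide, so a small fall in the number is expected. The estimated change is a 1.5-fold lower number from compound 1 to compound 4 (0.19 log units; within the scatter) and may not exceed the scatter. Compound 4 is expected at 5000 nM within a range of 2200 nM to 11000 nM when tested.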

Compound 4, half-maximal inhibitory concentration: 1200 nM
The estimate for compound 4 lay 4.2-fold (0.62 log units) above the measured number, outside the stated range (below it).
By their numbers in this assay, from the lowest: compound 4; then compounds 2 and 3 (each within the scatter of the next); then compound 1.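

In this assay, putting 3-fluorophenyl in place of 4-chlorophenyl on a saturated chain carbon bound to an oxygen on an aromatic ring gives a 6.4-fold lower number from compound 1 to compound 4 (0.81 log units; beyond the scatter) and shows that this part of the molecule alone can move the number. The earlier compounds shown here differ in more than one place and could not show this. Nothing measured here explains the shift.

This single change alters both the halogen and its ring position, and the compounds shown do not separate those two effects. From the compounds shown here alone, whether a methoxy group or an amine on this phenyl ring would give a similarly low number remains open.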